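Swapping cyclopentyl for pyridin-4-yl on the amine nitrogen

The compounds below may be only part of what the source reports. "The series", "measured", "known", "first", "only" and "open" are said of these compounds alone.

Three measured compounds carry a cyclopentyl group on an amine nitrogen: compound 1 (`COc1ccc(OCCOCCNC2CCCC2)cc1`), compound 2 (`c1ccc(COc2ccc(OCCOCCNC3CCCC3)cc2)cc1`) and compound 3 (`COc1ccc(COc2ccc(OCCOCCNC3CCCC3)cc2)cc1`). In a functional assay on SK-OV-3 cells (Homo sapiens) for inhibition, read by CCK-8 assay, with a stated time of 70 h (on this read-out higher numbers stand for weaker inhibition and lower numbers for stronger inhibition), compound 1 gives 99100 nM, compound 2 gives 24800 nM and compound 3 gives 15700 nM. Compound 2 therefore sits within the scatter of compound 3, and clearly under the number of compound 1.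

Compound 4 (`c1ccc(COc2ccc(OCCOCCNc3ccncc3)cc2)cc1`) has pyridin-4-yl in place of the cyclopentyl of compound 2 on that amine nitrogen: pyridin-4-yl in place of cyclopentyl on an amine nitrogen. The measured steps all change a different place. Two are modest and beyond the scatter, a 4.0-fold lower number from compound 1 to compound 2 (0.60 log units; beyond the scatter) and a 6.3-fold lower number from compound 1 to compound 3 (0.80 log units; beyond the scatter), while a 1.6-fold lower number from compound 2 to compound 3 (0.20 log units; within the scatter) stays within it. None of them tests the amine nitrogen, so the data give no direct guide to this swap, and no clear shift is expected in this assay. The expected step is a 1.1-fold lower number from compound 2 to compound 4 (0.05 log units; within the scatter), which would lie within the scatter. For compound 4 the estimated value is 22000 nM, with an expected range of 6500 nM to 70000 nM.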

Compound 4, half-maximal inhibitory concentration: 20600 nM
Compound 4: the middle estimate sits 1.1-fold (0.03 log units) above what was measured, and the stated range covers the measured number.
By their numbers in this assay, from the lowest: compounds 3, 4 and 2 (each within the scatter of the next); then compound 1.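

Going by these compounds alone, this is the first measured test of the group on the amine nitrogen, and in this assay the swap gives a 1.2-fold lower number from compound 2 to compound 4 (0.08 log units; within the scatter), so the two numbers cannot be told apart. On this core, then, a saturated carbon ring with no hydrogen-bond acceptor and an aromatic ring with a ring nitrogen and one hydrogen-bond acceptor give equivalent read-outs at this nitrogen, which shows that the position does not respond to this particular difference in ring type. Nothing measured here explains that outcome.

From the compounds shown here alone, this rests on a single pair, so it remains open whether the same swap would read the same way on the cores of compound 1 or compound 3. Going by these compounds, it is also open how this nitrogen would respond to pyridin-3-yl, or to a longer chain ending in a carboxylic acid.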